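Fluorine position on the ketone aryl group, compound 2 to 4

A few compounds are considered here, and "the series" means these few. Any claim that something is new, unique, unknown or untested is made for them only; others in the source may bear on it.

Measured so far in a functional assay on DLA cells (Mus musculus) for cytotoxicity, read by MTT assay, with a stated time of 48 h; on this read-out higher numbers stand for weaker inhibition and lower numbers for stronger inhibition:
compound 1 `Cc1cc(C(=O)c2ccccc2)ccc1OCC(=O)Nc1nc(-c2ccccc2)cs1` gives 22300 nM;
compound 2 `Cc1cc(C(=O)c2ccc(F)cc2)ccc1OCC(=O)Nc1nc(-c2ccccc2)cs1` gives 33300 nM;
compound 3 `COc1ccc(-c2csc(NC(=O)COc3ccc(C(=O)c4ccc(F)cc4)cc3C)n2)cc1` gives 5400 nM.

Compound 2 shows the highest of the three numbers. Its nearest neighbour is compound 1, with a 1.5-fold higher number from compound 1 to compound 2 (0.17 log units; within the scatter), so these two cannot be ordered. Compound 3 lies furthest off, with a 6.2-fold lower number from compound 2 to compound 3 (0.79 log units; beyond the scatter).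

Compound 4 `Cc1cc(C(=O)c2ccccc2F)ccc1OCC(=O)Nc1nc(-c2ccccc2)cs1` is not yet measured. Relative to compound 2 the change is 2-fluorophenyl in place of 4-fluorophenyl on a carbonyl carbon. Among the compounds with values here, the only measured step that touches this part of the molecule is the one from compound 1 to compound 2, a 1.5-fold higher number from compound 1 to compound 2 (0.17 log units; within the scatter), which shows that adding the fluorine itself left the number within the scatter. Within the data shown here, no measured pair differs only in where a substituent sits on the ring, so the direction of a positional shift cannot be read from these compounds. The expectation is therefore no step beyond the scatter, a 1.1-fold lower number from compound 2 to compound 4 (0.05 log units; within the scatter). Compound 4 is estimated at 30000 nM, with a range of 12000 nM to 75000 nM.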

Compound 4, half-maximal inhibitory concentration: 14800 nM
Compound 4: the middle estimate sits 2.0-fold (0.31 log units) above what was measured; measured number inside the range.
By their numbers in this assay, from the lowest: compound 3; then compounds 4, 1 and 2 (each within the scatter of the next, the first and the last beyond it).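

In this assay, within the data shown here, the position of the fluorine on the aryl group of the ketone separates two compounds for the first time: 2-fluorophenyl in place of 4-fluorophenyl on the carbonyl carbon gives a 2.3-fold lower number from compound 2 to compound 4 (0.35 log units; beyond the scatter), a modest step. Fluoro in place of hydrogen on an aromatic carbon gives a 1.5-fold lower number from compound 1 to compound 4 (0.18 log units; within the scatter), so compound 4, like compound 2, cannot be ordered against compound 1 even though the two fluorine isomers differ from each other. Nothing available explains the difference between the two isomers.

Still open, from the compounds shown here alone, is whether the same shift holds on the core of compound 3, which carries the methoxy group. Also open, going by these compounds, is how a carboxylic acid or a dimethylamino group would fare in place of the fluorine on this ring.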